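Replacing an acylurea with a methyl ester on a bicyclic nucleoside

The source may report more compounds than this note shows. Statements on the series, on what has been measured and on what is new or still open speak of the compounds shown alone.

Of the compounds shown here, three sharing one core have been tested in a functional assay on HEL cells (Homo sapiens) for cytotoxicity, read by microscopy; on this read-out lower numbers stand for higher toxicity in this test and higher numbers for lower toxicity in this test. Compound 1 `Cc1cn([C@@H]2O[C@H](CO[Si](C)(C)C(C)(C)C)[C@@]3(OS(=O)(=O)C=C3NCC(=O)O)[C@H]2O[Si](C)(C)C(C)(C)C)c(=O)n(C)c1=O` gives 300000 nM. Compound 2 `Cc1cn([C@@H]2O[C@H](CO[Si](C)(C)C(C)(C)C)[C@@]3(OS(=O)(=O)C=C3NCC(=O)C(=O)N3CCC3)[C@H]2O[Si](C)(C)C(C)(C)C)c(=O)n(C)c1=O` gives 65000 nM. Compound 3 `CCOC(=O)NC(=O)NC1=CS(=O)(=O)O[C@@]12[C@@H](CO[Si](C)(C)C(C)(C)C)O[C@@H](n1cc(C)c(=O)n(C)c1=O)[C@@H]2O[Si](C)(C)C(C)(C)C` gives 16000 nM, the lowest of the three numbers, so it is the most toxic compound seen so far in this assay; the steps of a 19-fold lower number from compound 1 to compound 3 (1.27 log units; beyond the scatter) and a 4.1-fold lower number from compound 2 to compound 3 (0.61 log units; beyond the scatter) both lie beyond the scatter.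

Compound 4 `COC(=O)CNC1=CS(=O)(=O)O[C@@]12[C@@H](CO[Si](C)(C)C(C)(C)C)O[C@@H](n1cc(C)c(=O)n(C)c1=O)[C@@H]2O[Si](C)(C)C(C)(C)C` is not yet measured. It differs from compound 3 at the amine nitrogen: (methoxycarbonyl)methyl in place of (ethoxycarbonyl)carbamoyl on an amine nitrogen. Compound 4 can also be read as the methyl ester of compound 1, since both carry a two-carbon chain ending in a carbonyl on that nitrogen.

Going by the values given here, two measured steps bear on this change. The step of a 19-fold lower number from compound 1 to compound 3 (1.27 log units; beyond the scatter) was large, and the step of a 4.1-fold lower number from compound 2 to compound 3 (0.61 log units; beyond the scatter) was modest, so every variation away from the (ethoxycarbonyl)carbamoyl group has so far raised the number. The step of a 4.6-fold lower number from compound 1 to compound 2 (0.66 log units; beyond the scatter) shows that capping the carbonyl of compound 1 lowers the number modestly. Compound 4 is therefore expected to land between compound 1 and compound 3, and the estimated step is a 4.4-fold higher number from compound 3 to compound 4 (0.64 log units; beyond the scatter). The expected value for compound 4 is 70000 nM, with a range from 15000 nM to 300000 nM.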

Compound 4, minimum cytotoxic concentration: >= 400000 nM
Compound 4: no number, only a limit; the forecaster's own chance of this, stated with the estimate: 10%; at least 5.7-fold (0.75 log units) between middle value and limit.
By their numbers in this assay, from the lowest: compound 3; then compound 2; then compound 1. At a limit, above all of these: compound 4.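

In this assay compound 4 gives no number, only a limit of the assay: the limit of >= 400000 nM in this assay, at which 1 of the 4 values shown sits. Even so, the change on the amine nitrogen has a clear effect: (methoxycarbonyl)methyl in place of (ethoxycarbonyl)carbamoyl gives an at least 25-fold higher number from compound 3 to compound 4 (1.39 log units; beyond the scatter), and the comparison with the azetidine amide gives an at least 6.1-fold higher number from compound 2 to compound 4 (0.78 log units; beyond the scatter), so the low numbers in this set belong to compound 3 and compound 2, not to every compound with a capped carbonyl. Going by these compounds alone, compound 4 is the counterexample that the earlier compounds lacked, since capping the acid of compound 1 as a methyl ester gives an at least 1.3-fold higher number from compound 1 to compound 4 (0.12 log units; that floor lies within the scatter), a floor within the scatter, and so shows no lowering of the kind seen with the azetidine amide and cannot place compound 4 and compound 1 in order.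

The limit leaves open how far compound 4 lies from compound 1 and how much lower toxicity it has, if any. From the compounds shown here alone, it also remains open which part of the (ethoxycarbonyl)carbamoyl group goes with the lower number, a question that a plain urea, a simple acetamide or an ethyl ester on the same nitrogen could help answer.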